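Swapping trifluoromethoxy for cyclopropyl in a glucagon receptor series

This account rests on a few compounds, and the source may have more. Where it says the series, first, only, none or still open, it means among the compounds named here.

Three compounds built on one shared core have been examined in an assay on CHO cells for displacement of a labelled ligand from Glucagon receptor (Homo sapiens), read by scintillation counting, with a stated time of 60 min; a higher number here means a weaker inhibitor, a lower number a stronger inhibitor. Compound 1 `C[C@H](c1ccc(C(=O)NCCC(=O)O)cc1)N1C(=O)C(c2cccc(OC(F)(F)F)c2)=N[C@]12CC[C@@H](C(C)(C)C)CC2` gives 330 nM in this assay, the highest number of the three. Compound 2 `CC1(CC[C@H](c2ccc(C(=O)NCc3nn[nH]n3)cc2)N2C(=O)C(c3cc(Cl)cc(Cl)c3)=N[C@]23CC[C@@H](C(C)(C)C)CC3)CC1` gives 17 nM and compound 3 `CCCCC[C@H](c1ccc(C(=O)NCc2nn[nH]n2)cc1)N1C(=O)C(c2cc(Cl)cc(Cl)c2)=N[C@]12CC[C@@H](C(C)(C)C)CC2` gives 24 nM in this assay, so compound 1 stands well apart from both, with each gap lying beyond the usual scatter.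

Going by the values given here, the only step between measured compounds that differ in one place is a 1.4-fold higher number from compound 2 to compound 3 (0.15 log units; within the scatter), which concerns propyl in place of 1-methylcyclopropyl on a saturated chain carbon, a site far from the aromatic ring that is altered below.

Compound 4 `C[C@H](c1ccc(C(=O)NCCC(=O)O)cc1)N1C(=O)C(c2cccc(C3CC3)c2)=N[C@]12CC[C@@H](C(C)(C)C)CC2` differs from compound 1 by cyclopropyl in place of trifluoromethoxy on an aromatic carbon, on an aromatic carbon of a six-membered aromatic ring of carbon only. Among the compounds with values here, no measured pair speaks directly to this exchange: the one step at hand touches another part of the molecule, and compound 2 and compound 3 each differ from compound 1 at more than one place. With nothing to point either way, compound 4 is expected to sit close to compound 1, and no change at the digits printed from compound 1 to compound 4 (within the scatter) is expected to stay within the scatter. Compound 4 is therefore estimated at 330 nM in this assay, with a range from 110 nM to 1000 nM.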

Compound 4, half-maximal inhibitory concentration: 56 nM
Estimate against measurement, compound 4: 5.9-fold (0.77 log units) above; measured number below the stated range.
By their numbers in this assay, from the lowest: compounds 2 and 3 (each within the scatter of the next); then compound 4; then compound 1.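

In this assay, going by these compounds alone, the aromatic carbon that carries trifluoromethoxy in the 3-(trifluoromethoxy)phenyl of compound 1 turns out to be a place where the number responds, a point the earlier compounds could not settle, as their one step lay on the saturated chain. Cyclopropyl in place of trifluoromethoxy gives a 5.9-fold lower number from compound 1 to compound 4 (0.77 log units; beyond the scatter), so an all-carbon three-membered ring is accepted at this place with the rest of the molecule unchanged, and compound 4 gives 56 nM without the oxygen and fluorine atoms of the departing group. Nothing available accounts for the size or direction of this step.

Whether isopropyl or methoxy at this place would read like cyclopropyl or like trifluoromethoxy remains open, so the compounds shown do not separate the effect of the entering ring from that of the leaving group. Also open, going by these compounds, is whether the same exchange would give a similar step in compound 2 or compound 3, which differ from compound 4 in more than one place.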